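Moving the methanesulfonamide on a thromboxane antagonist

A few compounds are considered here, and "the series" means these few. Any claim that something is new, unique, unknown or untested is made for them only; others in the source may bear on it.

Compound 1 `CS(=O)(=O)Nc1cccc(-c2ccc(COC3CC[C@H](N4CCCCCC4)[C@H]3OC/C=C\CCC(=O)O)cc2)c1` was examined in a functional assay for antagonist activity at thromboxane A2 receptor (Rattus norvegicus) (a lower number here means tighter binding, a higher number weaker binding), where compound 1 gives 50.1 nM. Compound 2 `O=C(O)CC/C=C\CO[C@H]1[C@@H](OCc2ccc(-c3ccc(CO)cc3)cc2)CC[C@@H]1N1CCCCCC1` gives 50.1 nM, a number level with that of compound 1 at the digits shown, and these two stand together as the highest of the three values. Compound 3 `O=C(O)CC/C=C\CO[C@@H]1C(OCc2ccc(-c3ccccc3)cc2)CC[C@@H]1N1CCCCC1` gives 15.9 nM, a lower number that lies beyond the usual scatter. Compound 4 `CS(=O)(=O)Nc1ccccc1-c1ccc(COC2CC[C@H](N3CCCCCC3)[C@H]2OC/C=C\CCC(=O)O)cc1` differs from compound 1 in one respect: 2-(methanesulfonamido)phenyl in place of 3-(methanesulfonamido)phenyl on an aromatic carbon. Among the measured compounds shown here, no measured pair shows this change on its own, so its effect remains open. Compound 4 is expected to show a modest step, a 1.6-fold higher number from compound 1 to compound 4 (0.20 log units; within the scatter), leaning toward a somewhat higher number but possibly none beyond the scatter. The estimate for compound 4 is 80 nM, with a range from 25 nM to 250 nM.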

Compound 4, dissociation constant: 3.98 nM
The estimate for compound 4 lay 20-fold (1.30 log units) above the measured number; the measured number lies below the stated range.
By their numbers in this assay, from the lowest: compound 4; then compound 3; then compounds 1 and 2 (each within the scatter of the next).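

In this assay, 2-(methanesulfonamido)phenyl in place of 3-(methanesulfonamido)phenyl gives a 13-fold lower number from compound 1 to compound 4 (1.10 log units; beyond the scatter). The two groups hold the same atoms, so at this place, para to a large group, where the methanesulfonamido group sits on the phenyl ring is enough to separate compound 1 from compound 4. No measurement at hand accounts for the size of this step. Going by these compounds, whether 4-(methanesulfonamido)phenyl would give a number close to that of compound 4 stays open. So does whether 2-carboxyphenyl or 2-cyanophenyl would keep the gain.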